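A few compounds are considered here, and "the series" means these few. Any claim that something is new, unique, unknown or untested is made for them only; others in the source may bear on it.

Compound 1 `COC[C@]1(C(=O)N2CC[C@](c3ccc(C(F)(C(F)(F)F)C(F)(F)F)cc3)(S(=O)(=O)c3ccc(F)cc3)C2)CC[C@H](C(=O)O)CC1` is the only point of reference with a number: in an ADME assay on microsomes from liver (Mus musculus) for metabolic stability, with a stated time of 10 min (a lower number here means that less of the compound is left, a higher number that more of the compound is left), compound 1 gives 88%. Compound 2 `O=C(O)[C@H]1CC[C@](F)(C(=O)N2CC[C@](c3ccc(C(F)(C(F)(F)F)C(F)(F)F)cc3)(S(=O)(=O)c3ccc(F)cc3)C2)CC1` shares the core of compound 1 but carries 4-carboxy-1-fluorocyclohexyl on the carbonyl carbon; in this assay compound 2 gives "not determined" (no result reported), so compound 2 has no standing on the numbers shown. Compound 3 `C[C@]1(C(=O)N2CC[C@](c3ccc(C(F)(C(F)(F)F)C(F)(F)F)cc3)(S(=O)(=O)c3ccc(F)cc3)C2)CC[C@@H](C(=O)O)CC1` has not yet been tested in this assay. Compound 3 differs from compound 2 in one place: 4-carboxy-1-methylcyclohexyl in place of 4-carboxy-1-fluorocyclohexyl on a carbonyl carbon. Among the measured compounds shown here, with no number for compound 2, no step between the two can be drawn, and the account expects the step in this assay from compound 2 to compound 3 to stay within the usual scatter rather than to move clearly in either direction. For the measured compounds named here, the only anchor is compound 1 with its 88%. Compound 3 is therefore estimated to give about 85% in this assay, within a range from 65% to 97%.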

Compound 3, percent of the compound remaining: 100%
Beside the measured number, compound 3's estimate is 15 percentage points below it; measured number above the stated range.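

In this assay, among the compounds shown here, replacing 4-carboxy-1-(methoxymethyl)cyclohexyl with 4-carboxy-1-methylcyclohexyl on the carbonyl carbon gives a number 12 percentage points higher from compound 1 to compound 3 (beyond the scatter), the first readable step at this position and one that shows the group on this carbonyl carbon can change the percent of compound remaining. The step involving compound 2 cannot be read, so 4-carboxy-1-fluorocyclohexyl has no place relative to the other two groups. Nothing given here offers a measured explanation for the step.

The compounds shown leave open how an ethyl or hydroxymethyl group would compare with the methyl of 4-carboxy-1-methylcyclohexyl. They also leave open whether this single step would hold on a core other than the shared one, or with a primary amide in place of the carboxylic acid.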